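Methyl for phenyl on the carbon double-bonded to nitrogen

A few compounds are considered here, and "the series" means these few. Any claim that something is new, unique, unknown or untested is made for them only; others in the source may bear on it.

Compound 1 `Oc1ccc(C2CC(c3ccccc3)=NN2c2ccc(Cl)cc2)cc1` is the reference point of the three measured compounds. In an assay on isolated protein for inhibition of protein kinase C zeta type (Homo sapiens), with a stated time of 4 min, tested at 62.5 uM (a higher number here means more inhibition at the concentration tested (going by the name of the read-out), a lower number less inhibition), compound 1 gives 95.6%, the highest of the three numbers. Compound 2 `Oc1ccc(C2CC(c3ccccc3)=NN2c2cccc(Cl)c2)cc1`, with 3-chlorophenyl in place of 4-chlorophenyl on an amine nitrogen in a ring, gives 90.5%; the step of a number 5.1 percentage points lower from compound 1 to compound 2 (within the scatter) lies within the scatter. Compound 3 `COc1ccc(C2CC(c3ccccc3)=NN2c2ccc(Cl)cc2)cc1`, with methyl in place of hydrogen on an oxygen on an aromatic ring, gives 21.1%; the step of a number 74.5 percentage points lower from compound 1 to compound 3 (beyond the scatter) is large and beyond the scatter.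

Compound 4 `CC1=NN(c2ccc(Cl)cc2)C(c2ccc(O)cc2)C1` has not been measured. It differs from compound 1 as follows: methyl in place of phenyl on a carbon with a double bond to nitrogen. Neither measured step touches the carbon with a double bond to nitrogen: the step to compound 2 concerns the chlorophenyl on the ring nitrogen, the step to compound 3 the oxygen on the aromatic ring. A phenyl leaves and a methyl enters; a loss of inhibition beyond the scatter is expected, of uncertain size. The estimate for compound 4 in this assay is 60%, within 20% to 95%, an expected step of a number 35.6 percentage points lower from compound 1 to compound 4 (beyond the scatter).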

Compound 4, a percentage reported as inhibition, at one concentration (the size of the read-out at that concentration, not a potency): 58.8%
The estimate for compound 4 lay 1.2 percentage points above the measured number; measured number inside the range.
By their numbers in this assay, from the lowest: compound 3; then compound 4; then compounds 2 and 1 (each within the scatter of the next).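

Methyl in place of phenyl on the carbon with a double bond to nitrogen gives a step of a number 36.8 percentage points lower from compound 1 to compound 4 (beyond the scatter) in this assay, so this position, untouched by the earlier steps, also bears on the read-out. The phenyl is not required for all inhibition at the concentration tested, since compound 4 still gives 58.8%. No measurement on these compounds accounts for the size of this step.

Going by these compounds, whether an ethyl, a cyclohexyl, a benzyl or a pyridyl group on this carbon would give a number nearer to that of compound 1 or that of compound 4 remains open. Also open, on these data alone, is whether the same exchange would give a similar step with the 3-chlorophenyl group of compound 2 on the ring nitrogen, or with the methoxy group of compound 3.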